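Rearranged pyridine ring on the shared core: permeability notes

The source may report more compounds than this note shows. Statements on the series, on what has been measured and on what is new or still open speak of the compounds shown alone.

Two compounds of the series carry a number in an ADME assay for permeability, using PAMPA; on this read-out higher numbers stand for higher permeability and lower numbers for lower permeability. Compound 1 `COc1ccc(Cl)c(-c2noc(C(C)C)c2COc2ccc(-c3ccc4c(C(=O)O)cn(C)c4c3)c(C)c2)n1` gives 0.7 10^-6 cm/s in this assay. Compound 2 `CC(C)c1onc(-c2c(Cl)cncc2Cl)c1COc1ccc(/C=C/c2cccc(C(=O)O)c2)c(Cl)c1` gives 0.09 10^-6 cm/s in this assay. Compound 1 thus stands highest of the two numbers, and its nearest neighbour, compound 2, sits a good way lower, beyond the scatter. For the measured compounds named here, no pair of measured compounds differs in one place only, so no measured step is at hand to lean on.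

Compound 3 `Cc1cc(OCc2c(-c3ccn(C)c(=O)c3Cl)noc2C(C)C)ccc1-c1ccc2c(C(=O)O)cn(C)c2c1` is the unmeasured member. It differs from compound 1 as follows: a group of 9 heavy atoms (6 carbon, 1 nitrogen, 1 oxygen, 1 chlorine; one six-membered aromatic ring with 1 hetero atom) in place of a group of 9 heavy atoms (6 carbon, 1 nitrogen, 1 oxygen, 1 chlorine; one six-membered aromatic ring with 1 hetero atom), on an aromatic carbon. The two compounds share every atom and differ only in how these are joined; the group that enters brings one double bond outside aromatic rings where the 3-chloro-6-methoxypyridin-2-yl group that leaves has none.

Going by the values given here, with no step of this kind measured, the expectation for compound 3 is a modest drop from compound 1, a 2.3-fold lower number from compound 1 to compound 3 (0.37 log units; beyond the scatter), with the direction less certain than the size. Compound 3 is therefore estimated at 0.3 10^-6 cm/s in this assay, with a range from 0.08 10^-6 cm/s to 1 10^-6 cm/s.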

Compound 3, apparent permeability: "not active" (no number reported)
The entry for compound 3 holds no number; there is nothing to compare the estimate with.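

In this assay, for the compounds shown here, the entry for compound 3 reads "not active" and holds no number, so no step from compound 1 to compound 3 can be read. The compounds shown leave open how swapping the 3-chloro-6-methoxypyridin-2-yl group for its rearranged isomer shifts this read-out. No supporting evidence bears on this result.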